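Swapping Methyl for Benzyl on the Amide Nitrogen

The source may report more compounds than this note shows. Statements on the series, on what has been measured and on what is new or still open speak of the compounds shown alone.

Measured compounds in a functional assay on K562 cells (Homo sapiens) for antiproliferative activity, read by MTT assay, with a stated time of 48 h; a higher number here means a weaker inhibitor, a lower number a stronger inhibitor:
- compound 1 `CN1C(=O)C2(C(C#N)=C(N)Oc3cc4oc(-c5ccccc5)cc(=O)c4c(O)c32)c2cc(Cl)ccc21` gives 4340 nM
- compound 2 `CN1C(=O)C2(C(C#N)=C(N)Oc3cc4oc(-c5ccccc5)cc(=O)c4c(O)c32)c2cc(Br)ccc21` gives 4100 nM
- compound 3 `Cc1cccc2c1N(Cc1ccccc1)C(=O)C21C(C#N)=C(N)Oc2cc3oc(-c4ccccc4)cc(=O)c3c(O)c21` is reported only as a limit of the assay, > 50000 nM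

Among the two compounds with a number, compound 1 has the highest value; compound 2 is the nearest, and the step of a 1.1-fold lower number from compound 1 to compound 2 (0.02 log units; within the scatter) lies within the scatter, so the two cannot be told apart. The value for compound 3 is a limit of the assay rather than a number (the limit of > 50000 nM in this assay, at which 1 of the 3 values shown sits).

Compound 4 `N#CC1=C(N)Oc2cc3oc(-c4ccccc4)cc(=O)c3c(O)c2C12C(=O)N(Cc1ccccc1)c1ccc(Cl)cc12` is not yet measured. It differs from compound 1 by phenyl in place of hydrogen on a saturated chain carbon bound to an amide-type nitrogen in a ring; cut one bond further out, this reads methyl to benzyl. Among the measured compounds shown here, the only measured step, a 1.1-fold lower number from compound 1 to compound 2 (0.02 log units; within the scatter), concerns a halogen swap and so does not bear directly on this change. Compound 3 also carries a benzyl on its amide-type nitrogen in a ring, alongside other differences, and its value is a limit. This suggests the number for compound 4 is expected to rise, likely beyond the scatter, with a real chance that only a limit is reported. The estimate for compound 4 is 15000 nM, within 4000 nM to 60000 nM, meaning an expected step of a 3.5-fold higher number from compound 1 to compound 4 (0.54 log units; beyond the scatter).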

Compound 4, half-maximal inhibitory concentration: 36300 nM
For compound 4 the middle estimate is 2.4-fold (0.38 log units) below the measured one; the range from low to high includes it.
By their numbers in this assay, from the lowest: compounds 2 and 1 (each within the scatter of the next); then compound 4. At a limit, above all of these: compound 3.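

In this assay, methyl to benzyl on the amide-type nitrogen in a ring, with the rest of the molecule unchanged, gives an 8.4-fold higher number from compound 1 to compound 4 (0.92 log units; beyond the scatter), so what sits at this position clearly affects the antiproliferative read-out and the larger group here gives the weaker inhibitor. Among the compounds shown here, the halogen swap said nothing about this nitrogen, and compound 3 differs from compound 1 in more than one place, so this is the first number tied to the benzyl change alone. Compound 3 also carries a benzyl at this nitrogen, but its value is only a limit of the assay: the limit of > 50000 nM in this assay, at which 1 of the 4 values shown sits.

With only methyl and benzyl shown on this nitrogen, it stays open whether the added phenyl ring itself matters, or whether a plain longer chain such as butyl would give a similar number. Also open, from the compounds shown here alone, is where the amide hydrogen or a chain ending in an amine or a carboxylic acid would fall.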